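This account rests on a few compounds, and the source may have more. Where it says the series, first, only, none or still open, it means among the compounds named here.

Within the data shown here, compound 2 `CCO[C@H]1C[C@@H](c2coc3ccc(C)cc3c2=O)N(c2ccccc2)O1` gives 39000 nM in a functional assay on PC-3 cells (Homo sapiens) for inhibition, read by sulforhodamine B assay, with a stated time of 48 h; a lower number here means a stronger inhibitor, a higher number a weaker inhibitor; compound 1 `CCO[C@H]1C[C@@H](c2coc3ccc(F)cc3c2=O)N(c2ccccc2)O1` gives 31700 nM in this assay, and the two stand within the scatter of one another, the sole measured step being a 1.2-fold higher number from compound 1 to compound 2 (0.09 log units; within the scatter). Compound 3 `CCO[C@H]1C[C@@H](c2coc3ccc(Br)cc3c2=O)N(c2ccccc2)O1` differs from compound 2 by bromo in place of methyl on an aromatic carbon. Among the measured compounds shown here, no measured step swaps methyl for bromo, but since a 1.2-fold higher number from compound 1 to compound 2 (0.09 log units; within the scatter) showed nothing beyond the scatter for a fluoro-to-methyl swap at the same place, no step beyond the scatter is expected here either. Compound 3 is therefore estimated at 32000 nM, range 12000 nM to 90000 nM, an expected step of a 1.2-fold lower number from compound 2 to compound 3 (0.09 log units; within the scatter).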

Compound 3, half-maximal inhibitory concentration: > 60000 nM
Compound 3: only a limit was reported; the forecaster's own chance of this, stated with the estimate: 10%; middle value at least 1.8-fold (0.27 log units) from the limit.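

In this assay compound 3 gives > 60000 nM, which is a limit and not a number, the first in this series at this position. The steps to bromo, an at least 1.5-fold higher number from compound 2 to compound 3 (0.18 log units; that floor lies within the scatter) and an at least 1.8-fold higher number from compound 1 to compound 3 (0.27 log units; that floor lies within the scatter), are floors only, so the change is not yet shown to exceed the scatter, though the true gaps may be larger. The reading is bounded from one side only: the limit of > 60000 nM in this assay, at which 1 of the 3 values shown sits.

Still open, from the compounds shown here alone, is how far bromo actually lies from methyl and fluoro. Also open, going by these compounds, is whether an amine or a carboxylic acid at this place would move the number beyond the scatter.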